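Adding a Hydroxy Group to Compound 2

The source may hold more compounds than are shown below. What is called first, only, known or untested is meant among the compounds shown, and "the series" means these compounds.

Compound 2 `COc1ccc(-c2ccccc2)cc1` gives > 100 ug/mL in a functional assay on MCF7 cells (Homo sapiens) for cytotoxicity, read by MTT assay, with a stated time of 3 days (on this read-out higher numbers stand for weaker inhibition and lower numbers for stronger inhibition), which is a limit of the assay and not a number. The data shown include (the limit of > 100 ug/mL in this assay, at which 1 of the 3 values shown sits).

Compound 4 `COc1ccc(-c2cccc(O)c2)cc1` differs from compound 2 by hydroxy in place of hydrogen on an aromatic carbon, meta to a group of 8 heavy atoms (hydroxy in place of hydrogen on an aromatic carbon). Two other compounds that carry hydroxy give numbers in this assay: compound 1 `Nc1cccc(-c2cccc(O)c2)c1` gives 99 ug/mL and compound 3 `Nc1ccccc1-c1ccc(O)cc1` gives 44.3 ug/mL. Both also carry an amino group, which compound 4 lacks, so they offer only a loose guide. Within the data shown here, no measured step isolates the hydroxy group, and the starting point is only a limit. A modest move towards stronger inhibition is therefore expected, and it may not clearly exceed the scatter. The expected step of an at least 1.6-fold lower number from compound 2 to compound 4 (0.22 log units; that floor lies within the scatter) is an estimate resting on these values. For compound 4 the estimated value is 60 ug/mL, with an expected range of 25 ug/mL to 100 ug/mL.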

Compound 4, half-maximal inhibitory concentration: 48 ug/mL
Compound 4: middle estimate off by 1.3-fold (0.10 log units), on the high side; measured number inside the range.
By their numbers in this assay, from the lowest: compounds 3 and 4 (each within the scatter of the next); then compound 1. At a limit, above all of these: compound 2.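

In this assay, hydroxy in place of hydrogen on an aromatic carbon, meta to a group of 8 heavy atoms, gives an at least 2.0-fold lower number from compound 2 to compound 4 (0.31 log units; beyond the scatter). Among these compounds, this is the first step that isolates the hydroxy group, since the earlier hydroxy compounds also carried an amino group, and it shows that this single change, with no amino group present, lies beyond the scatter. Compound 2 gives > 100 ug/mL, which is a limit of the assay and not a number, so the step is only a floor and its full size cannot be read: the limit of > 100 ug/mL in this assay, at which 1 of the 4 values shown sits.

The compounds shown leave open whether hydroxy gives a similar step at other places on that ring, and whether a carboxylic acid or an amine in the same place would do so. They also leave open whether the step would hold on a core without the methoxy group.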